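The source may hold more compounds than are shown below. What is called first, only, known or untested is meant among the compounds shown, and "the series" means these compounds.

Compound 1 `CC#CC(CC(=O)O)c1ccc(OCC2COc3ccc(Cl)cc3O2)cc1`: 100 nM
Compound 2 `CCOC(CC(=O)O)c1ccc(OCC2COc3ccc(Cl)cc3O2)cc1`: 640 nM
Compound 3 `O=C(O)CC(c1ccc(OCC2COc3ccc(Cl)cc3O2)cc1)c1cnco1`: 1030 nM

In a functional assay on HEK293 cells for agonist activity at Free fatty acid receptor 1 (Homo sapiens), read by fluorescence and calcium flux, with a stated time of 10 min (on this read-out higher numbers stand for an effect only at larger amounts of compound and lower numbers for an effect already at smaller amounts), compound 1 stands with the lowest of the three numbers. The steps of a 6.4-fold higher number from compound 1 to compound 2 (0.81 log units; beyond the scatter) and a 10-fold higher number from compound 1 to compound 3 (1.01 log units; beyond the scatter) both lie beyond the scatter, while the step of a 1.6-fold higher number from compound 2 to compound 3 (0.21 log units; within the scatter) does not. Compound 4 `CC#C[C@H](CC(=O)O)c1ccc(OC[C@@H]2COc3ccc(Cl)cc3O2)cc1` differs from compound 1 only in how its stereocentres are drawn: the two compounds have the same atoms and bonds; at least one stereo element is drawn with a configuration in one of them and without one in the other: 2 of 2 stereo elements differ; a stereocentre at a saturated chain carbon is drawn without a configuration in compound 1 and R in compound 4; a stereocentre at a saturated ring carbon is drawn without a configuration in compound 1 and R in compound 4. Among the measured compounds shown here, none of the measured steps touches a stereo element; each of them exchanges a group on the chain carbon, so they offer no guide to this change. A single enantiomer may hold more or less of the activity of the unresolved material. For compound 4 a step not beyond the scatter is expected, a 1.7-fold lower number from compound 1 to compound 4 (0.22 log units; within the scatter). Compound 4 is therefore estimated at 60 nM, within 20 nM to 300 nM.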

Compound 4, half-maximal effective concentration: 5040 nM
Compound 4: middle estimate off by 84-fold (1.92 log units), on the low side; measured number above the stated range.
By their numbers in this assay, from the lowest: compound 1; then compounds 2 and 3 (each within the scatter of the next); then compound 4.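

Drawing both stereocentres as R, with atoms and bonds unchanged, gives a 50-fold higher number from compound 1 to compound 4 (1.70 log units; beyond the scatter) in this assay. The earlier compounds shown here varied only the group on the chain carbon, whereas this result shows that the number also answers to configuration, and that the R,R form does not carry the activity of compound 1. Stereochemistry is the only difference to point to: the fact that one of compounds 1 and 4 is drawn with a defined configuration and the other without, at the place where they differ

Which of the two stereocentres accounts for the step remains open, as does the standing of the S forms. Also open, from the compounds shown here alone, is whether a chain carbon bearing cyclopropyl would show the same dependence on configuration.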